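Replacing the Fluorophenyl Group of a Potent Cytotoxic Compound

The compounds below may be only part of what the source reports. "The series", "measured", "known", "first", "only" and "open" are said of these compounds alone.

For the measured compounds named here, in a functional assay on MCF7 cells (Homo sapiens) for cytotoxicity, read by MTT assay, with a stated time of 96 h (on this read-out lower numbers stand for stronger inhibition and higher numbers for weaker inhibition), compound 3 `COc1cc(C(=O)c2cn(-c3ccc(N)cc3)cc2-c2ccccc2F)cc(OC)c1OC` gives 28 nM, the lowest number of the three compounds measured so far. Compound 1 `COc1cc(C(=O)c2cn(-c3cccc(C)c3)cc2-c2cccc([N+](=O)[O-])c2)cc(OC)c1OC` gives 880 nM, and compound 2 `COc1cc(C(=O)c2cn(-c3cccc(N)c3)cc2-c2cccc([N+](=O)[O-])c2)cc(OC)c1OC` gives 510 nM. Compound 4 `COc1cc(C(=O)c2cn(-c3ccc(N)cc3)cc2-c2cccc([N+](=O)[O-])c2)cc(OC)c1OC` has not yet been measured, and it departs from compound 3 in one place: 3-nitrophenyl in place of 2-fluorophenyl on an aromatic carbon.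

Going by the values given here, only one measured step is available, a 1.7-fold lower number from compound 1 to compound 2 (0.24 log units; within the scatter). It swaps methyl for amino rather than touching the group that changes here, so it offers no direct guide. Its main use is to show that these two compounds cannot be told apart in this assay.

The closer clue is that compound 1 and compound 2 both carry the incoming 3-nitrophenyl group, and both give much higher numbers than compound 3. However, they also differ from compound 3 in the group on the ring nitrogen, so the data cannot separate the two changes. Some loss of potency is therefore expected, though probably not all of that gap.

The expected size of the change is a 4.3-fold higher number from compound 3 to compound 4 (0.63 log units; beyond the scatter), which is an estimate towards a higher number. For compound 4, the estimated value is 120 nM, with an expected range from 30 nM to 500 nM.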

Compound 4, half-maximal inhibitory concentration: 260 nM
Compound 4: middle estimate off by 2.2-fold (0.34 log units), on the low side; the measured number falls inside the stated range.
By their numbers in this assay, from the lowest: compound 3; then compounds 4, 2 and 1 (each within the scatter of the next, the first and the last beyond it).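

For the compounds shown here, with 4-aminophenyl kept on the ring nitrogen, 3-nitrophenyl in place of 2-fluorophenyl gives a 9.3-fold higher number from compound 3 to compound 4 (0.97 log units; beyond the scatter) in this assay, so the change at this position can now be read on its own, which no earlier pair allowed. With 3-nitrophenyl kept in place, the group on the ring nitrogen can also be read: 4-aminophenyl in place of 3-aminophenyl gives a 2.0-fold lower number from compound 2 to compound 4 (0.29 log units; within the scatter), so those two compounds cannot be told apart, whereas 4-aminophenyl in place of 3-methylphenyl gives a 3.4-fold lower number from compound 1 to compound 4 (0.53 log units; beyond the scatter), a real but modest step. Nothing measured here accounts for the size of any of these steps.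

Going by these compounds, it remains open whether the step from 2-fluorophenyl to 3-nitrophenyl would keep its size with 3-aminophenyl or 3-methylphenyl on the ring nitrogen, since 2-fluorophenyl appears here only with 4-aminophenyl. Also open, on these data alone, is how this position would respond to a plain phenyl ring, to 3-fluorophenyl or 2-nitrophenyl, which would separate the identity of the group from its place on the ring, or to a phenyl ring carrying a methoxy group or an amine.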